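This account rests on a few compounds, and the source may have more. Where it says the series, first, only, none or still open, it means among the compounds named here.

Compound 2 `CCCN(CC[C@H]1CC[C@H](NC(=O)c2cccc(-n3ccnc3)c2)CC1)[C@H]1CCc2nc(N)sc2C1` carries an amide on a shared core. Going by the values given here, in an assay on brain for displacement of a labelled ligand from D(3) dopamine receptor (Rattus norvegicus) (on this read-out higher numbers stand for weaker inhibition and lower numbers for stronger inhibition), compound 2 gives 1.1 nM, which is nominally the lower of the two numbers measured so far, although its gap to compound 1 `CCCN(CC[C@H]1CC[C@H](NC(=O)/C=C/c2ccccc2Cl)CC1)[C@H]1CCc2nc(N)sc2C1`, which in this assay gives 1.2 nM, is within the scatter. Among the compounds with values here, the only measured step, a 1.1-fold lower number from compound 1 to compound 2 (0.04 log units; within the scatter), exchanged one amide-bound group for another without any change beyond the scatter. Compound 3 `CCCN(CC[C@H]1CC[C@H](NC(=O)c2ccc(-c3noc(C)n3)cc2)CC1)[C@H]1CCc2nc(N)sc2C1` differs from compound 2 in one place: 4-(5-methyl-1,2,4-oxadiazol-3-yl)phenyl in place of 3-(1H-imidazol-1-yl)phenyl on a carbonyl carbon. That single step is the only one that bears on this exchange, and it was small. Compound 3 is therefore expected to show a change of a 1.2-fold higher number from compound 2 to compound 3 (0.07 log units; within the scatter) in this assay, not beyond the scatter. Compound 3 is expected to give about 1.3 nM in this assay, within a range from 0.5 nM to 3.5 nM.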

Compound 3, inhibition constant: 1.3 nM
Compound 3: the middle estimate sits on the measured number at the digits printed; low and high end bracket the measured number.
By their numbers in this assay, from the lowest: compounds 2, 1 and 3 (each within the scatter of the next).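

In this assay, placing 4-(5-methyl-1,2,4-oxadiazol-3-yl)phenyl on the carbonyl carbon gives a 1.2-fold higher number from compound 2 to compound 3 (0.07 log units; within the scatter), and the same group gives a 1.1-fold higher number from compound 1 to compound 3 (0.03 log units; within the scatter). A third group, whose five-membered ring holds an oxygen that neither earlier group contains, therefore leaves the read-out within the scatter, so this position has now accepted three different groups with no change beyond it. Nothing measured here explains this lack of change.

Going by these compounds, all three groups carry a six-membered aromatic ring of carbon only, so it remains open whether the read-out would hold with a plain methyl, or with a phenyl bearing a carboxylic acid or an amine. The two ring groups also differ in both their numbering and their five-membered ring, so the effect of either difference alone cannot be separated.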